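The source may report more compounds than this note shows. Statements on the series, on what has been measured and on what is new or still open speak of the compounds shown alone.

Measured compounds so far:
Compound 1, `O=C(/C=C/c1coc2cc(O)ccc2c1=O)NCc1ccc(F)cc1`. In a functional assay on L02 cells (Homo sapiens) for inhibition, read by MTT assay, with a stated time of 48 h (a lower number here means a stronger inhibitor, a higher number a weaker inhibitor), compound 1 gives > 200000 nM, which is a limit of the assay and not a number.
Compound 2, `COc1ccc2c(=O)c(/C=C/C(=O)Nc3ccc(Cl)cc3)coc2c1`. In this assay compound 2 gives > 200000 nM, again a limit of the assay.
Compound 3, `Cc1ccccc1NC(=O)/C=C/c1coc2cc(O)ccc2c1=O`. In this assay compound 3 gives > 200000 nM, also a limit of the assay.

Compound 2 therefore stands at the limit, with no number of its own, and the same holds for every value in the set, as the limit of > 200000 nM in this assay, at which 3 of the 3 values shown sit, shows. Nothing on the numbers separates compound 2 from compound 1 or from compound 3. Within the data shown here, the one step between measured compounds that differ in a single place, a step that the two limits leave unreadable from compound 1 to compound 3, is unreadable, both ends being limits.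

Compound 4, `COc1ccc2c(=O)c(/C=C/C(=O)Nc3ccccc3OC)coc2c1`, is the next candidate. It differs from compound 2 by 2-methoxyphenyl in place of 4-chlorophenyl on an amide-type nitrogen. Among the measured compounds shown here, no measured step bears directly on this change; the only step on the same amide-type nitrogen, a step that the two limits leave unreadable from compound 1 to compound 3, gives no size. With every value at the limit, no step beyond the scatter is expected in this assay in either direction, and compound 4 is expected to sit at the limit as well. The estimate for compound 4 is 200000 nM, with a range from 100000 nM to 400000 nM. The step this estimate means for compound 4 is a number no higher from compound 2 to compound 4 (the limit leaves the size open), expected to be none readable.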

Compound 4, half-maximal inhibitory concentration: > 200000 nM
Compound 4: a limit, no number; the forecaster's own chance of this, stated with the estimate: 85%; the middle value lies on the limit itself.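

No step can be read from compound 2 to compound 4, since both ends are limits of the assay and not numbers: the limit of > 200000 nM in this assay, at which 4 of the 4 values shown sit.

The compounds shown leave open what number any of them would have in this assay, and whether any change on the amide-type nitrogen alters it.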